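This account rests on a few compounds, and the source may have more. Where it says the series, first, only, none or still open, it means among the compounds named here.

Measured so far in an ADME assay on Vero cells (Chlorocebus sabaeus) for cytotoxicity; a lower number here means that less compound is tolerated, a higher number that more compound is tolerated:
compound 1 `O[C@@H]1Cc2cc(Cl)ccc2N[C@H](c2cccs2)C1` gives 164000 nM;
compound 2 `Cc1ccc([C@@H]2C[C@H](O)Cc3cc(Cl)ccc3N2)s1` gives 154000 nM;
compound 3 `O[C@@H]1Cc2ccccc2N[C@H](c2ccco2)C1` gives > 1300000 nM, which is a limit of the assay rather than a number.

Compound 1 and compound 2 share one core and differ only by methyl in place of hydrogen on an aromatic carbon, a change that gave a 1.1-fold lower number from compound 1 to compound 2 (0.03 log units; within the scatter), so the two values stand within the usual scatter of each other. Compound 3 carries a different core; the difference between the two cores is not broken down here. Compound 4 `Cc1ccc([C@@H]2C[C@H](O)Cc3ccccc3N2)o1` has not yet been tested in this assay. It differs from compound 3 by methyl in place of hydrogen on an aromatic carbon. This is the same kind of change as that from compound 1 to compound 2, though around a ring with one oxygen, next to the ring oxygen, rather than a ring with one sulfur, next to the ring sulfur. Since that earlier methyl step stayed within the scatter, a step of similar size, a step that the limit leaves unreadable from compound 3 to compound 4, is expected from compound 3 to compound 4. Given that compound 3 sits at the limit of > 1300000 nM in this assay, at which 1 of the 3 values shown sits, compound 4 is estimated at 1500000 nM, and a further limit value is quite possible.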

Compound 4, half-maximal cytotoxic concentration: 370000 nM
Compound 4: the middle estimate sits 4.1-fold (0.61 log units) above what was measured; the whole stated range lies above it.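

In this assay, going from furan-2-yl to 5-methylfuran-2-yl gives an at least 3.5-fold lower number from compound 3 to compound 4 (0.54 log units; beyond the scatter). A methyl in place of a hydrogen therefore does not carry over at the same size between these two cores, yet this rests on only two pairs, and they differ both in the ring bearing the methyl (one oxygen rather than one sulfur) and elsewhere in the core, so the data cannot say which difference matters: the same change on two cores in this assay, a 1.1-fold lower number (0.03 log units; within the scatter) from compound 1 to compound 2 and an at least 3.5-fold lower number (0.54 log units; beyond the scatter) from compound 3 to compound 4, at least 3.2-fold (0.51 log units) apart, beyond the scatter of two such steps

The value of compound 3 is a limit of the assay and not a number, so the full size of its step remains unknown: the limit of > 1300000 nM in this assay, at which 1 of the 4 values shown sits.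

The compounds shown leave open whether the lower number seen with compound 4 would also appear with another group in the same place, such as an ethyl, a longer chain or an amine. They also leave open how a methyl would behave on a ring with one oxygen when the rest of the core matches compound 1.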